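The source may hold more compounds than are shown below. What is called first, only, known or untested is meant among the compounds shown, and "the series" means these compounds.

Measured so far in an assay on liver for inhibition of sterol O-acyltransferase 1 (Rattus norvegicus), using microsomes; on this read-out higher numbers stand for weaker inhibition and lower numbers for stronger inhibition:
compound 1 `CCCCCCCCCCCCn1nnc(C(C(=O)Nc2ccc(F)cc2F)c2ccccc2)n1`: 31 nM
compound 2 `CCCCCCCCCCCCn1nnc(C(C(=O)Nc2c(OC)ncnc2OC)c2ccccc2)n1`: 13 nM

Among the compounds with values here, compound 2 holds the lower of the two numbers in this assay; the only other compound, compound 1, stands at a 2.4-fold lower number from compound 1 to compound 2 (0.38 log units; beyond the scatter), a modest gap. Compound 3 `CCCCCCCCCCCCn1nnc(C(C(=O)Nc2ccc3c(C)cc(C)nc3n2)c2ccccc2)n1` is the next compound to be measured. Its change from compound 2 is a group of 12 heavy atoms (10 carbon, 2 nitrogen; 2 six-membered aromatic rings with 1 hetero atom each) in place of a group of 10 heavy atoms (6 carbon, 2 nitrogen, 2 oxygen; one six-membered aromatic ring with 2 hetero atoms), on an amide-type nitrogen. Within the data shown here, only one measured step bears on this change: the step from compound 1 to compound 2, which also replaced the group on the amide-type nitrogen and gave a 2.4-fold lower number from compound 1 to compound 2 (0.38 log units; beyond the scatter). Among the measured compounds shown here, that step exchanged one six-membered aromatic ring for another, whereas compound 3 brings in two fused rings; no measured pair shows such a swap, so the direction cannot be read from the data. Compound 3 is therefore expected to remain near compound 2, with a 1.2-fold higher number from compound 2 to compound 3 (0.06 log units; within the scatter) inside the usual scatter. The estimated value of compound 3 in this assay is 15 nM, within a range of 5 nM to 50 nM.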

Compound 3, half-maximal inhibitory concentration: 1540 nM
For compound 3 the middle estimate is 100-fold (2.01 log units) below the measured one, and the stated range ends below it.
By their numbers in this assay, from the lowest: compound 2; then compound 1; then compound 3.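

At this position on the amide-type nitrogen in this assay, the size of the effect is far larger than the earlier exchange of one single-ring group for another had shown. Bringing in the two-ring group gives a 120-fold higher number from compound 2 to compound 3 (2.07 log units; beyond the scatter) and also a 50-fold higher number from compound 1 to compound 3 (1.70 log units; beyond the scatter), so the loss appears against both single-ring groups, whether the ring that leaves is of carbon only or holds two hetero atoms. The position therefore tolerates the two single-ring groups but not this two-ring group, and no available information accounts for the difference.

Within the data shown here, with only this one two-ring group at hand, it remains open whether the second ring or the methyl groups on it carry the loss. A plain quinoline or a single pyridine ring at this position would begin to separate the two.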